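The source may hold more compounds than are shown below. What is called first, only, known or untested is meant among the compounds shown, and "the series" means these compounds.

In a functional assay on WM 266-4 cells (Homo sapiens) for antiproliferative activity, read by MTT assay, with a stated time of 48 h (on this read-out higher numbers stand for weaker inhibition of growth and lower numbers for stronger inhibition of growth), compound 1 `CSc1ccc(C2=NN(C(=S)Nc3ccccc3)C(c3ccc4c(c3)OCCO4)C2)cc1` gives 197000 nM. Compound 2 `S=C(Nc1ccccc1)N1N=C(c2cccc(Cl)c2)CC1c1ccc2c(c1)OCCO2` reaches only > 200000 nM, which is a limit of this assay and not a number, as the limit of > 200000 nM in this assay, at which 1 of the 2 values shown sits, records. The step of an at least 1.0-fold higher number from compound 1 to compound 2 (0.00 log units; that floor lies within the scatter) lies within the scatter. Compound 3 `S=C(Nc1ccccc1)N1N=C(c2ccc(Cl)c(Cl)c2)CC1c1ccc2c(c1)OCCO2` differs from compound 2 by chloro in place of hydrogen on an aromatic carbon, reading 3-chlorophenyl to 3,4-dichlorophenyl. The one measured step shown, an at least 1.0-fold higher number from compound 1 to compound 2 (0.00 log units; that floor lies within the scatter), offers no change beyond the scatter, so compound 3 is expected to stay near the limit, with an estimated step of a number no higher from compound 2 to compound 3 (the limit leaves the size open). Compound 3 is estimated at 200000 nM, between 100000 nM and 400000 nM.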

Compound 3, concentration for 50% growth inhibition: 58700 nM
Compound 3: middle estimate off by 3.4-fold (0.53 log units), on the high side; the whole stated range lies above it.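

Chloro in place of hydrogen on the aromatic carbon ortho to a chloro group and para to a large group gives the first change beyond the scatter in this assay, with an at least 3.4-fold lower number from compound 2 to compound 3 (0.53 log units; beyond the scatter). That step is only a floor, since compound 2 stands at a limit of the assay and not at a number: the limit of > 200000 nM in this assay, at which 1 of the 3 values shown sits. The 3,4-dichlorophenyl group also reads apart from the 4-(methylsulfanyl)phenyl group, with a 3.4-fold lower number from compound 1 to compound 3 (0.53 log units; beyond the scatter).

The compounds shown leave open how a 4-chlorophenyl group alone would read. They also leave open whether an amine or a methoxy group at this position would give a similar number.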